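Swapping a bromine for a chlorine on a triply substituted core

The source may hold more compounds than are shown below. What is called first, only, known or untested is meant among the compounds shown, and "the series" means these compounds.

Measured compounds:
- compound 1, `Cc1cc(O)c(C(=O)/C=C/c2ccc(Cl)cc2)c(-c2ccccc2)c1C(=O)/C=C/c1ccc(Cl)cc1`: 30000 nM
- compound 2, `Cc1cc(O)c(C(=O)/C=C/c2ccc(Cl)cc2)c(-c2ccc(Br)cc2)c1C(=O)/C=C/c1ccc(Cl)cc1`: 32000 nM
- compound 3, `Cc1cc(O)c(C(=O)/C=C/c2ccc(OCc3ccccc3)cc2)c(-c2ccc(Br)cc2)c1C(=O)/C=C/c1ccc(OCc2ccccc2)cc1`: "not active" (no number reported)

All three compounds were tested in a functional assay on HeLa cells (Homo sapiens) for cytotoxicity, read by MTT assay, with a stated time of 24 h; a higher number here means a weaker inhibitor, a lower number a stronger inhibitor. Compound 2 gives the higher of the two reported numbers, and its nearest neighbour is compound 1; the step of a 1.1-fold higher number from compound 1 to compound 2 (0.03 log units; within the scatter) is within the scatter, so the two cannot be ranked. Compound 3 was reported as not active, with no number given.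

Compound 4, `Cc1cc(O)c(C(=O)/C=C/c2ccc(Cl)cc2)c(-c2ccc(Cl)cc2)c1C(=O)/C=C/c1ccc(Cl)cc1`, has not been measured. It differs from compound 2 in one place: chloro in place of bromo on an aromatic carbon.

Among the measured compounds shown here, only one measured step bears on this change. Adding a bromine at the same spot, going from compound 1 to compound 2, was a 1.1-fold higher number from compound 1 to compound 2 (0.03 log units; within the scatter), a difference within the scatter. A swap of one halogen for another at that spot is a smaller change than putting a halogen where there was none, so no step beyond the scatter is expected in this assay in either direction.

Compound 4 is therefore expected to give 31000 nM in this assay, within a range of 15000 nM to 65000 nM, an expected step of a 1.0-fold lower number from compound 2 to compound 4 (0.01 log units; within the scatter).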

Compound 4, half-maximal inhibitory concentration: "not active" (no number reported)
Compound 4 has no reported number here; there is nothing to compare the estimate with.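

In this assay, among the compounds shown here, compound 4 was reported as not active, with no number, so no step from compound 2 to compound 4 can be read. No measurement shown here accounts for this result. The compounds shown leave open how far, if at all, 4-chlorophenyl and 4-bromophenyl differ in this cell test.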